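Taking the methyl off the amine of compound 2

The compounds below may be only part of what the source reports. "The series", "measured", "known", "first", "only" and "open" are said of these compounds alone.

In an ADME assay on the whole organism (Rattus norvegicus, strain Sprague-Dawley) for pharmacokinetics, read by LC-MS, with a stated time of 24 h, at a dose of 2 mg/kg by the intravenous route (on this read-out lower numbers stand for slow clearance and higher numbers for fast clearance), the two measured compounds read as follows.
Compound 1 `Cn1nc2c(=O)n(CC3(O)CCN(Cc4ccc(-c5ccco5)cc4Cl)CC3)cnc2c1-c1ccc(CNC=O)cc1` gives 30 mL/min/kg
Compound 2 `CNCc1ccc(-c2c3ncn(CC4(O)CCN(Cc5ccc(-c6ccco6)cc5Cl)CC4)c(=O)c3nn2C)cc1` gives 107 mL/min/kg

Compound 2 has the higher clearance of this pair. Among the measured compounds shown here, the one measured step at this amine nitrogen is a 3.6-fold higher number from compound 1 to compound 2 (0.55 log units; beyond the scatter) with methyl in place of formyl. Compound 3 `Cn1nc2c(=O)n(CC3(O)CCN(Cc4ccc(-c5ccco5)cc4Cl)CC3)cnc2c1-c1ccc(CN)cc1` arises from compound 2 by a different change (hydrogen in place of methyl on an amine nitrogen), hydrogen in place of methyl on an amine nitrogen. For the measured compounds named here, no measured step covers this exact swap, so only a weak guide exists. A smaller move than the measured one is expected, toward lower clearance (a 1.5-fold lower number from compound 2 to compound 3 (0.18 log units; within the scatter)), possibly within the scatter. Compound 3 is estimated at 70 mL/min/kg (range 35 mL/min/kg to 130 mL/min/kg).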

Compound 3, clearance: 100 mL/min/kg
Compound 3: the middle estimate sits 1.4-fold (0.15 log units) below what was measured; low and high end bracket the measured number.
By their numbers in this assay, from the lowest: compound 1; then compounds 3 and 2 (each within the scatter of the next).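

In this assay, hydrogen in place of methyl on the amine nitrogen gives a 1.1-fold lower number from compound 2 to compound 3 (0.03 log units; within the scatter), so the two groups read alike at this position. Hydrogen in place of formyl gives a 3.3-fold higher number from compound 1 to compound 3 (0.52 log units; beyond the scatter), which leaves compound 1, the only one of the three with a formyl on this nitrogen, standing apart from the other two.

Still open, as far as these compounds go, is how other groups on this nitrogen, such as an acetyl or a longer chain, would read, and whether they would fall with the formyl or with the methyl and hydrogen. Nothing measured here explains why the formyl compound stands apart.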